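The source may report more compounds than this note shows. Statements on the series, on what has been measured and on what is new or still open speak of the compounds shown alone.

Compound 1 `NC(=O)c1ccc(NC(=O)c2cc3ccccc3s2)cc1` gives 25 ug/mL in a physicochemical assay for solubility; on this read-out higher numbers stand for higher solubility and lower numbers for lower solubility. Compound 2 `COC(=O)c1ccc(NC(=O)c2cc3cc([N+](=O)[O-])ccc3s2)cc1` gives 10 ug/mL in this assay, and compound 3 `O=C(Nc1ccccc1)c1cc2cc([N+](=O)[O-])ccc2s1` gives 10 ug/mL. Compound 3 therefore stands level with compound 2, the two of them together giving the lowest numbers of the three, while compound 1 gives a higher number that lies beyond the scatter. For the measured compounds named here, the only step between measured compounds that differ in one place is no change at the digits printed from compound 2 to compound 3 (within the scatter), where the group left an aromatic carbon of the same ring.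

Compound 4 `COC(=O)c1cccc(NC(=O)c2cc3cc([N+](=O)[O-])ccc3s2)c1` differs from compound 3 by methoxycarbonyl in place of hydrogen on an aromatic carbon. This change is the reverse in kind of the step from compound 2 to compound 3, though the group enters at a different carbon of the ring, and that step produced no change beyond the scatter. On this basis the step of no change at the digits printed from compound 3 to compound 4 (within the scatter) is expected to fall within the scatter. Compound 4 is accordingly estimated at 10 ug/mL, with a range from 5 ug/mL to 20 ug/mL.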

Compound 4, solubility: 25 ug/mL
Compound 4: the middle estimate sits 2.5-fold (0.40 log units) below what was measured; the measured number lies above the stated range.
By their numbers in this assay, from the lowest: compounds 2 and 3 (each within the scatter of the next); then compounds 1 and 4 (each within the scatter of the next).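

In this assay, methoxycarbonyl in place of hydrogen on this carbon, meta to a large group, does not leave the number unchanged: the step is a 2.5-fold higher number from compound 3 to compound 4 (0.40 log units; beyond the scatter). The earlier step, which concerned the same group on a different carbon of the same ring, did not show this, so the carbon carrying the group now appears to matter: compound 2 gives 10 ug/mL, while compound 4 gives 25 ug/mL. Nothing available here accounts for this difference.

From the compounds shown here alone, whether a different group on this carbon, such as a carboxylic acid, an amine or a longer ester chain, would move the number as methoxycarbonyl does remains open. Going by these compounds, it is also open whether the same step would appear on a core without the nitro group.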